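A Hydroxy Exchanged on the Shared Core

A few compounds are considered here, and "the series" means these few. Any claim that something is new, unique, unknown or untested is made for them only; others in the source may bear on it.

Measured in a functional assay on HCT-8 cells (Homo sapiens) for antiproliferative activity, read by sulforhodamine B assay, with a stated time of 48 h; on this read-out higher numbers stand for weaker inhibition and lower numbers for stronger inhibition:
- Compound 1 `COc1ccc(/C=C/C(=O)c2ccccc2-c2ccc(F)cc2)cc1`: 230 nM
- Compound 2 `COc1ccc(/C=C/C(=O)c2ccccc2-c2ccc(F)cc2)cc1O`: 420 nM

For the measured compounds named here, compound 2, at 420 nM, stands within the scatter of compound 1, the only other compound measured, so the two numbers show no order. Compound 3 `COc1ccc(/C=C/C(=O)c2ccccc2-c2ccc(F)cc2)cc1B(O)O` differs from compound 2 by one change: a group of 3 heavy atoms (1 boron, 2 oxygen; no ring) in place of one oxygen atom, on an aromatic carbon. The exchange falls on an aromatic carbon ortho to a methoxy group and meta to a large group. Going by the values given here, the only measured step that bears on it is a 1.8-fold higher number from compound 1 to compound 2 (0.26 log units; within the scatter), made by hydroxy in place of hydrogen on an aromatic carbon. Among the compounds with values here, no measurement yet covers the entering group, so this single step is weak evidence and the range must stay wide. In this assay, no step beyond the scatter is expected, and no direction is favoured with confidence. The estimated change is a 1.2-fold lower number from compound 2 to compound 3 (0.08 log units; within the scatter). For compound 3 the expected value is 350 nM, with an estimated range of 90 nM to 1300 nM.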

Compound 3, half-maximal inhibitory concentration: 84 nM
Compound 3: middle estimate off by 4.2-fold (0.62 log units), on the high side; measured number below the stated range.
By their numbers in this assay, from the lowest: compound 3; then compounds 1 and 2 (each within the scatter of the next).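

In this assay, for the compounds shown here, the aromatic carbon ortho to a methoxy group now proves responsive to what it carries: the group of boron and two oxygen atoms in place of hydroxy gives a 5.0-fold lower number from compound 2 to compound 3 (0.70 log units; beyond the scatter) and is the first step beyond the scatter. The same group in place of hydrogen gives a 2.7-fold lower number from compound 1 to compound 3 (0.44 log units; beyond the scatter) and also lies beyond the scatter, whereas hydroxy in place of hydrogen stayed within it, so a change at this carbon can shift the number only with some groups. Nothing measured here accounts for the shift.

The compounds shown do not tell how a carboxylic acid or an amine on the same carbon would read. They also leave open whether the boron group would give a similar step on another carbon of this ring.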